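Swapping the aryl ring on the cinnamate ester of compound 2

The source may hold more compounds than are shown below. What is called first, only, known or untested is meant among the compounds shown, and "the series" means these compounds.

Compound 1 `Cc1ccc(/C=C/C(=O)Oc2ccc(/C=C3\CCCCC3=O)cc2)cc1` and compound 2 `Cc1ccc(/C=C/C(=O)Oc2ccc(/C=C3\CCCC(CN(C)C)C3=O)cc2)cc1` share a core that differs only at a saturated ring carbon. In a functional assay on MOLT-4 cells (Homo sapiens) (on this read-out lower numbers stand for stronger inhibition and higher numbers for weaker inhibition), compound 1 gives 156000 nM, and in this assay compound 2 gives 3390 nM. Among the compounds with values here, the one measured step, a 46-fold lower number from compound 1 to compound 2 (1.66 log units; beyond the scatter), comes with (dimethylamino)methyl in place of hydrogen on a saturated ring carbon. Compound 2 therefore stands at the lowest of the two numbers, far from compound 1.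

Compound 3 `CN(C)CC1CCC/C(=C\c2ccc(OC(=O)/C=C/c3ccc(Cl)c(Cl)c3)cc2)C1=O` keeps that (dimethylamino)methyl group and changes a different place: 3,4-dichlorophenyl in place of 4-methylphenyl on a double-bonded chain carbon bound to a double-bonded chain carbon. Within the data shown here, no measured pair touches the aryl ring at the far end of the ester, so the single step from compound 1 to compound 2 does not bear on this change. With nothing in the data to point one way or the other, the account expects for compound 3 a step of a 1.1-fold lower number from compound 2 to compound 3 (0.05 log units; within the scatter) that stays within the usual scatter. On that basis compound 3 is estimated in this assay at 3000 nM, with a range from 900 nM to 10000 nM.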

Compound 3, half-maximal inhibitory concentration: 4570 nM
The estimate for compound 3 lay 1.5-fold (0.18 log units) below the measured number; the measured number falls inside the stated range.
By their numbers in this assay, from the lowest: compounds 2 and 3 (each within the scatter of the next); then compound 1.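

In this assay the exchange of 4-methylphenyl for 3,4-dichlorophenyl on a double-bonded chain carbon bound to a double-bonded chain carbon gives a 1.3-fold higher number from compound 2 to compound 3 (0.13 log units; within the scatter) and so leaves compound 2 and compound 3 indistinguishable on this read-out. This is the first reading at this position, and it shows that a chlorinated aryl group can stand there with the (dimethylamino)methyl group kept in place and no step beyond the scatter, whereas the earlier step at the saturated ring carbon, a 46-fold lower number from compound 1 to compound 2 (1.66 log units; beyond the scatter) remains the only large one among the compounds shown. Nothing supplied here explains why the two aryl groups read alike.

The compounds shown leave open whether this tolerance extends to other groups in the same place, such as 4-methoxyphenyl, 4-nitrophenyl, a 4-carboxyphenyl group or an unsubstituted phenyl ring. They also leave open whether 3,4-dichlorophenyl would read the same on the core of compound 1, which lacks the (dimethylamino)methyl group, and whether a pyrrolidine or a morpholine could take the place of the dimethylamino part of that group.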